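Changing the group on the ring nitrogen of compound 3

The compounds below may be only part of what the source reports. "The series", "measured", "known", "first", "only" and "open" are said of these compounds alone.

The compounds share a core on which an amide-type nitrogen in a ring carries a varying group. Compound 1 `O=C(NCCCCc1ccccc1)c1cccc(C2SCC(=O)N2c2cnccn2)c1` carries pyrazin-2-yl there; in a functional assay on HOS-TE85 cells (Homo sapiens) for inhibition, read by CCK-8 assay, with a stated time of 72 h (on this read-out lower numbers stand for stronger inhibition and higher numbers for weaker inhibition), compound 1 gives only a limit, > 1000 nM (the limit of > 1000 nM in this assay, at which 1 of the 3 values shown sits). Compound 2 `O=C(NCCCCc1ccccc1)c1cccc(C2SCC(=O)N2c2ccccn2)c1` carries pyridin-2-yl and gives 19.7 nM in this assay. Compound 3 `C#Cc1cccc(N2C(=O)CSC2c2cccc(C(=O)NCCCCc3ccccc3)c2)c1` carries 3-ethynylphenyl and gives 149 nM, the highest of the two numbers shown; the step of a 7.6-fold higher number from compound 2 to compound 3 (0.88 log units; beyond the scatter) is beyond the scatter, and the step of an at least 6.7-fold lower number from compound 1 to compound 3 (0.82 log units; beyond the scatter) is set against a limit.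

Compound 4 `O=C(NCCCCc1ccccc1)c1cccc(C2SCC(=O)N2c2ccc(C3CC3)cc2)c1` differs from compound 3 by 4-cyclopropylphenyl in place of 3-ethynylphenyl on an amide-type nitrogen in a ring. The steps that change the group on this nitrogen, an at least 50-fold lower number from compound 1 to compound 2 (1.70 log units; beyond the scatter) and a 7.6-fold higher number from compound 2 to compound 3 (0.88 log units; beyond the scatter), were both beyond the scatter, so a change at this place can move the number well in either direction. Among the compounds with values here, no measured step replaces one six-membered aromatic ring of carbon only by another, so the direction here is uncertain. The expected step is a 1.3-fold higher number from compound 3 to compound 4 (0.13 log units; within the scatter). Compound 4 is therefore estimated at roughly 200 nM, between 40 nM and 1000 nM.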

Compound 4, half-maximal inhibitory concentration in the HOS-TE85 assay: 217 nM
The estimate for compound 4 lay 1.1-fold (0.04 log units) below the measured number, and the stated range covers the measured number.
By their numbers in the HOS-TE85 assay, from the lowest: compound 2; then compounds 3 and 4 (each within the scatter of the next). At a limit, above all of these: compound 1.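

In the HOS-TE85 assay there is a 1.5-fold higher number from compound 3 to compound 4 (0.16 log units; within the scatter), so exchanging one carbon-only aromatic ring for the other on this nitrogen gives no step beyond the scatter, yet in a physicochemical assay for solubility, read by turbidimetry, measured as kinetic solubility, at pH 7.4 (on this read-out lower numbers stand for lower solubility and higher numbers for higher solubility), the same change comes with lower solubility: the measured solubility of compound 3, 10000 nM, and of compound 4, 2000 nM, a 5.0-fold lower number (0.70 log units; beyond the scatter). In the physicochemical assay compound 3 gives 10000 nM and compound 4 gives 2000 nM. In the HOS-TE85 assay there is an 11-fold higher number from compound 2 to compound 4 (1.04 log units; beyond the scatter), so compound 4, like compound 3, stays clear of the number of compound 2 with pyridin-2-yl. Compound 1 gives only a limit, so an at least 4.6-fold lower number from compound 1 to compound 4 (0.66 log units; beyond the scatter) is a bound and not a measured size.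

The compounds shown leave open whether pyridin-2-yl carrying a cyclopropyl group would keep the number of compound 2. They also leave open how a phenyl ring carrying an amine or a carboxylic acid would stand in either read-out.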